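Swapping an Aryl Ether for a Piperazine on a Weak Cytotoxin

The source may report more compounds than this note shows. Statements on the series, on what has been measured and on what is new or still open speak of the compounds shown alone.

Measured so far:
- compound 1 `CC1=NN(C(=O)COc2ccc(Cl)cc2)C(c2ccccc2O)C1` gives 38800 nM
- compound 2 `CC1=NN(C(=O)COc2ccc(Cl)cc2)C(c2cc(Br)ccc2O)C1` gives 49000 nM
- compound 3 `CC1=NN(S(=O)(=O)c2ccc([N+](=O)[O-])cc2)C(c2cc(Br)cc(Br)c2O)C1` gives 50000 nM

All three numbers come from a functional assay on PC-3 cells (Homo sapiens) for cytotoxicity, read by MTT assay, with a stated time of 48 h; on this read-out higher numbers stand for weaker inhibition and lower numbers for stronger inhibition. Compound 1 sits at the low end of the three values, but every gap among them lies within the usual scatter of repeated measurements, so none of the three can be called more or less potent than the others. For the measured compounds named here, the only single change that links two measured compounds is a 1.3-fold higher number from compound 1 to compound 2 (0.10 log units; within the scatter), which shows that adding a bromine to the phenol ring leaves the read-out essentially where it was. Compound 3, with a sulfonyl group in place of the amide and two bromines, gives a value that is likewise indistinguishable from compounds 1 and 2.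

Compound 4 `CC1=NN(C(=O)CN2CCN(C)CC2)C(c2ccccc2O)C1` is not yet measured. It differs from compound 1 by 4-methylpiperazin-1-yl in place of 4-chlorophenoxy on a saturated chain carbon bound to a carbonyl carbon. Going by the values given here, no measured step touches this part of the molecule, so nothing in the existing numbers points to a change in either direction. The expectation is therefore that compound 4 stays close to compound 1, with the estimated step being a 1.2-fold higher number from compound 1 to compound 4 (0.06 log units; within the scatter). On that basis compound 4 is estimated at 45000 nM, within a range of 15000 nM to 150000 nM.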

Compound 4, half-maximal inhibitory concentration: 11800 nM
For compound 4 the middle estimate is 3.8-fold (0.58 log units) above the measured one; the whole stated range lies above it.
By their numbers in this assay, from the lowest: compound 4; then compounds 1, 2 and 3 (each within the scatter of the next).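

In this assay, for the compounds shown here, putting 4-methylpiperazin-1-yl in place of 4-chlorophenoxy on a saturated chain carbon bound to a carbonyl carbon gives a 3.3-fold lower number from compound 1 to compound 4 (0.52 log units; beyond the scatter), the only step in this set that lies beyond the scatter. The read-out can therefore respond to a change at this position, something the bromo step, a 1.3-fold higher number from compound 1 to compound 2 (0.10 log units; within the scatter), did not show at its own site. The size of the step is modest, and the data on hand offer no explanation for it.

The swap removes an aromatic ring of carbon only and brings in a non-aromatic ring with hetero atoms, so the compounds shown leave open whether the gain comes from losing 4-chlorophenoxy or from gaining the piperazine, and a morpholin-4-yl or a dimethylamino group at the same place would help to separate the two. Also open, on these data alone, is whether the same swap would give a similar step on compound 2, which carries a bromo group on the core, or whether the step holds only for the core of compound 1.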